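Series notes: aryl substitution on the fused core, in vivo

The source may hold more compounds than are shown below. What is called first, only, known or untested is meant among the compounds shown, and "the series" means these compounds.

Measured so far:
- compound 1 `Cc1ccc2c(c1)c(C1CCN(CCN3CCNC3=O)CC1)cn2-c1ccc(F)cc1`: 0.0083 umol/kg
- compound 2 `CN1CCN(CCN2CCC(c3cn(-c4ccc(F)cc4)c4ccc(Cl)cc34)CC2)C1=O`: 0.021 umol/kg

In a functional assay on the whole organism for inhibition, with Rattus norvegicus as the target (on this read-out higher numbers stand for an effect only at larger amounts of compound and lower numbers for an effect already at smaller amounts), compound 1 gives 0.0083 umol/kg, the lowest of the two values at hand. In this assay compound 2 gives 0.021 umol/kg, a higher number, and the gap between the two lies beyond the scatter; compound 2 also differs from compound 1 in more than one place, so the two values are only set side by side here.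

Compound 3 `COc1ccc2c(c1)c(C1CCN(CCN3CCNC3=O)CC1)cn2-c1ccc(F)cc1` carries methoxy in place of methyl on an aromatic carbon on the shared core of compound 1. Going by the values given here, no measured pair in the set isolates this change, so the direction is open. The expectation is a small step, likely none beyond the scatter, with a lean towards a somewhat higher number: the step from compound 1 to compound 3 is estimated at a 1.4-fold higher number from compound 1 to compound 3 (0.16 log units; within the scatter). For compound 3 in this assay the estimate is 0.012 umol/kg, with a range from 0.004 umol/kg to 0.04 umol/kg.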

Compound 3, dose for half-maximal effect: 0.77 umol/kg
The estimate for compound 3 lay 64-fold (1.81 log units) below the measured number; the whole stated range lies below it.
By their numbers in this assay, from the lowest: compound 1; then compound 2; then compound 3.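

Exchanging methyl for methoxy on this aromatic carbon of the shared core gives, in this assay, a 93-fold higher number from compound 1 to compound 3 (1.97 log units; beyond the scatter), so this position is far from indifferent to the group it carries. The exchange is small by count, with 1 heavy atom leaving and 2 heavy atoms entering, yet the step lies well beyond the scatter. No available measurement accounts for the size of this step.

This single pair cannot separate the contribution of the oxygen from that of the extra heavy atom; an ethyl group or a hydroxyl group on the same carbon would help to tell these apart. On these data alone, whether the same exchange has a similar effect with a methyl group on the urea ring nitrogen, as carried by compound 2, also remains open.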